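Swapping the Ring on the Amide Nitrogen: Expected Solubility

This account rests on a few compounds, and the source may have more. Where it says the series, first, only, none or still open, it means among the compounds named here.

Compound 1 `CNC(=O)c1cc(C(=O)NC2CCOCC2)cn(Cc2ccccc2)c1=O` has been tested in a physicochemical assay for solubility; a higher number here means a more soluble compound, a lower number a less soluble compound. Compound 1 gives >= 174 ug/mL, which is a limit of the assay rather than an exact number, so compound 1 stands at the upper edge of what this assay could report. Compound 2 `CNC(=O)c1cc(C(=O)NC2CC2)cn(Cc2cccc(C)c2)c1=O` likewise reaches a limit, at >= 205 ug/mL. Compound 3 `CNC(=O)c1cc(C(=O)NC2CC2)cn(Cc2cccc(OC)c2)c1=O` gives 79 ug/mL. For the measured compounds named here, the only step measured between neighbouring compounds runs an at least 2.5-fold lower number from compound 2 to compound 3 (0.41 log units; beyond the scatter); that change sits on the aromatic ring, far from the amide nitrogen, so it says little about what a change at the nitrogen would do.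

Compound 4 `CNC(=O)c1cc(C(=O)NC2CCC2)cn(Cc2ccccc2)c1=O` has not yet been measured. It differs from compound 1 by cyclobutyl in place of oxan-4-yl on an amide-type nitrogen. Going by the values given here, no measured pair shows this particular change, so there is no direct guide to its size or direction; the data only show that both compound 1 and compound 2, which differ from each other at this nitrogen and on the aromatic ring, sit at the limit. Compound 4 is therefore expected to remain reasonably soluble, with an estimated 110 ug/mL and a plausible range from 40 ug/mL to 250 ug/mL, which would correspond to an expected step of an at least 1.5-fold lower number from compound 1 to compound 4 (0.19 log units; that floor lies within the scatter).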

Compound 4, solubility: 28 ug/mL
For compound 4 the middle estimate is 3.9-fold (0.59 log units) above the measured one, and the stated range ends above it.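

In this assay, cyclobutyl in place of oxan-4-yl on an amide-type nitrogen gives an at least 6.2-fold lower number from compound 1 to compound 4 (0.79 log units; beyond the scatter). For the compounds shown here, the one earlier step came from a change on the aromatic ring, so this is the first direct sign that the group on this nitrogen can move the read-out by more than the scatter, and with the shared core left unchanged. Compound 1 stands at a limit of the assay, so the step is only a floor and the real difference could be larger: the limit of >= 174 ug/mL in this assay, at which 1 of the 4 values shown sits.

This single pair does not tell whether the loss of the ring oxygen or the change from a six-membered to a four-membered ring counts for more, since both happen in the same swap. A cyclohexyl group, which keeps the six-membered ring without the oxygen, and an oxetan-3-yl group, which places an oxygen in a four-membered ring, would pull those two changes apart if set on the same nitrogen.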